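Bromo in Place of Cyano on a Non-Toxic Amide

A few compounds are considered here, and "the series" means these few. Any claim that something is new, unique, unknown or untested is made for them only; others in the source may bear on it.

Compound 3 `COc1ccc(-c2cnc(NC(=O)c3cccc(C#N)c3)n2C)cc1` was tested in a toxicity assay on THP-1 cells (Homo sapiens) for inhibition; on this read-out higher numbers stand for lower toxicity in this test and lower numbers for higher toxicity in this test. Compound 3 gives > 100000 nM, which is a limit of the assay rather than a number. Compound 1 `COc1ccc(-c2cnc(NC(=O)c3ccccc3F)n2C)cc1` likewise gives only a limit, > 100000 nM. Compound 2 `COc1ccc(-c2cnc(NC(=O)CCc3ccccc3)n2C)cc1` also gives a limit, > 100000 nM. Because all three values sit at the limit of > 100000 nM in this assay, at which 3 of the 3 values shown sit, the steps a step that the two limits leave unreadable from compound 1 to compound 2, a step that the two limits leave unreadable from compound 1 to compound 3 and a step that the two limits leave unreadable from compound 2 to compound 3 cannot be sized. Compound 4 `COc1ccc(-c2cnc(NC(=O)c3cccc(Br)c3)n2C)cc1` differs from compound 3 by bromo in place of cyano on an aromatic carbon. No measured step bears on this change, and none of the three shown can be read. The step from compound 3 to compound 4 is therefore expected to be a number no higher from compound 3 to compound 4 (the limit leaves the size open), nothing beyond the scatter. Compound 4 is expected to give about 100000 nM, between 50000 nM and 200000 nM, most likely again only a limit.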

Compound 4, half-maximal cytotoxic concentration: > 100000 nM
Compound 4: a limit, no number; the forecaster's own chance of this, stated with the estimate: 75%; the middle value lies on the limit itself.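

Compound 4 gives > 100000 nM as a limit of the assay, so its steps from compound 1, compound 2 and compound 3 cannot be read: the limit of > 100000 nM in this assay, at which 4 of the 4 values shown sit.

On these data alone, whether this assay would separate these four compounds at all stays open.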